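Halogen swap on the ring-nitrogen group of compound 2

The compounds below may be only part of what the source reports. "The series", "measured", "known", "first", "only" and "open" are said of these compounds alone.

Going by the values given here, compound 2 `Nc1scc(CN2CCN(c3ccc(F)cc3Cl)CC2)c1C(=O)c1ccc(Cl)cc1` and compound 1 `Nc1scc(CN2CCN(c3cc(Cl)cc(Cl)c3)CC2)c1C(=O)c1ccc(Cl)cc1` are the two compounds measured so far. In a functional assay on CHO cells with adenosine receptor A1 (Homo sapiens) as the target, read by cAMP accumulation and immunoassay, with a stated time of 6 min, tested at 10 uM (a higher number here means a weaker effect of the compound at the concentration tested, a lower number a stronger effect), compound 2 gives -70% and compound 1 gives -74%; the step of a number 4 percentage points higher from compound 1 to compound 2 (within the scatter) lies within the scatter. Compound 3 `Nc1scc(CN2CCN(c3ccc(Cl)cc3F)CC2)c1C(=O)c1ccc(Cl)cc1` differs from compound 2 by 4-chloro-2-fluorophenyl in place of 2-chloro-4-fluorophenyl on an amine nitrogen in a ring. Among the compounds with values here, the one measured step that bears on it, a number 4 percentage points higher from compound 1 to compound 2 (within the scatter), exchanged the group on the same ring nitrogen without a shift beyond the scatter, so for compound 3 no step beyond the scatter is expected in this assay, no change at the digits printed from compound 2 to compound 3 (within the scatter). Compound 3 is therefore estimated at -70%, between -85% and -55%.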

Compound 3, a percentage reported as activity, at one concentration (the size of the read-out at that concentration, not a potency): -81%
The estimate for compound 3 lay 11 percentage points above the measured number; the range from low to high includes it.
By their numbers in this assay, from the lowest: compounds 3, 1 and 2 (each within the scatter of the next, the first and the last beyond it).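

In this assay, swapping chlorine and fluorine on the same phenyl gives a number 11 percentage points lower from compound 2 to compound 3 (beyond the scatter) with the same atoms joined differently, so this position responds to where the halogens stand on the ring, which the earlier pair could not show. Replacing 3,5-dichlorophenyl with 4-chloro-2-fluorophenyl gives a number 7 percentage points lower from compound 1 to compound 3 (within the scatter) and so does not separate those two groups. Nothing at hand accounts for the step between the two halogen arrangements.

Still open, going by these compounds, is whether a phenyl bearing a methoxy group or a nitrile would hold the number seen with compound 3 on this ring nitrogen.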